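Swapping a Sulfonamide for an Acetamide on the Core

The compounds below may be only part of what the source reports. "The series", "measured", "known", "first", "only" and "open" are said of these compounds alone.

Three compounds share one core and differ only in the group on its aromatic ring. Compound 1 `CN1CCN(CCCN(C(=O)Nc2ccc(F)c(Cl)c2)C2CCc3cc(C#N)ccc3C2)CC1` carries a nitrile and gives 340 nM in an assay on CHO cells for binding affinity to melanin-concentrating hormone receptor 1 (Homo sapiens); a lower number here means a stronger inhibitor, a higher number a weaker inhibitor. Compound 2 `CN1CCN(CCCN(C(=O)Nc2ccc(F)c(Cl)c2)C2CCc3ccc(S(C)(=O)=O)cc3C2)CC1` carries a methylsulfonyl group and gives 1300 nM in this assay. Compound 3 `CNS(=O)(=O)c1ccc2c(c1)CC(N(CCCN1CCN(C)CC1)C(=O)Nc1ccc(F)c(Cl)c1)CC2` carries a methylsulfamoyl group and gives 3000 nM, the highest number of the three and therefore the weakest binder here; its nearest neighbour is compound 2, and compound 1 lies furthest away.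

Compound 4 `CC(=O)Nc1ccc2c(c1)CC(N(CCCN1CCN(C)CC1)C(=O)Nc1ccc(F)c(Cl)c1)CC2` is the next step from compound 3: acetamido in place of methylsulfamoyl on an aromatic carbon. Among the compounds with values here, no measured pair shows this exact exchange. The closest measured step, a 2.3-fold higher number from compound 2 to compound 3 (0.36 log units; beyond the scatter), changed only a small part of the sulfonyl group and moved the number modestly. The change to compound 4 is of similar scale, trading one small hydrogen-bond donor group for another, so a step of a 1.7-fold lower number from compound 3 to compound 4 (0.22 log units; within the scatter) is expected, close to the scatter. Compound 4 is estimated at 1800 nM, in a range from 600 nM to 5000 nM.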

Compound 4, inhibition constant: 6 nM
The estimate for compound 4 lay 300-fold (2.48 log units) above the measured number, and the stated range ends above it.
By their numbers in this assay, from the lowest: compound 4; then compound 1; then compound 2; then compound 3.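

This position on the aromatic ring is far more sensitive to its substituent than the sulfonyl compounds suggested: in this assay acetamido in place of methylsulfamoyl gives a 500-fold lower number from compound 3 to compound 4 (2.70 log units; beyond the scatter) and acetamido in place of methylsulfonyl gives a 220-fold lower number from compound 2 to compound 4 (2.34 log units; beyond the scatter) as well. The earlier 2.3-fold higher number from compound 2 to compound 3 (0.36 log units; beyond the scatter) within the sulfonyl pair gave no hint of a change this large. Methylsulfamoyl and acetamido each carry one hydrogen-bond donor and differ by only one heavy atom, so a close match in these counts did not mean a close match in binding.

Nothing available explains this gain. Going by these compounds, it also remains open how much of the acetamido group is needed, which a plain amine or a propionamido group with its longer chain at this position could help to show.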